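Oxadiazole isomer exchange from compound 3 to compound 4

A few compounds are considered here, and "the series" means these few. Any claim that something is new, unique, unknown or untested is made for them only; others in the source may bear on it.

Half-lives in an ADME assay on the whole organism for metabolic stability, with Rattus norvegicus as the target (a higher number here means that the compound lasts longer, a lower number that the compound disappears faster), so far
- compound 1 `CCOC(=O)c1ccc(N2C(=O)C(O)=C(C(=O)c3ccc(OC)cc3)C2c2ccc(F)cc2)cc1` gives 0.1 h
- compound 2 `COc1ccc(C(=O)C2=C(O)C(=O)N(c3ccc(-c4noc(C)n4)cc3)C2C2CCCCC2)cc1` gives 0.8 h
- compound 3 `COc1ccc(C(=O)C2=C(O)C(=O)N(c3ccc(-c4nc(C)no4)cc3)C2C2CCCCC2)cc1` gives 1 h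

Compound 3 lies within the scatter of compound 2 and beyond the scatter above compound 1. Compound 4 `COc1ccc(C(=O)C2=C(O)C(=O)N(c3ccc(-c4nnc(C)o4)cc3)C2C2CCCCC2)cc1` differs from compound 3 by 5-methyl-1,3,4-oxadiazol-2-yl in place of 3-methyl-1,2,4-oxadiazol-5-yl on an aromatic carbon on an aromatic carbon, para to a large group. Among the measured compounds shown here, one measured step bears on this: the exchange of 5-methyl-1,2,4-oxadiazol-3-yl for 3-methyl-1,2,4-oxadiazol-5-yl gave a 1.3-fold higher number from compound 2 to compound 3 (0.10 log units; within the scatter) and stayed within the scatter. For the measured compounds named here, no measured compound carries 5-methyl-1,3,4-oxadiazol-2-yl, so this rests on one precedent. The expected result is no change at the digits printed from compound 3 to compound 4 (within the scatter) and thus nothing beyond the scatter. Compound 4 is estimated at 1 h in this assay (range 0.4 h to 2.5 h).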

Compound 4, half-life: 1.7 h
Estimate against measurement, compound 4: 1.7-fold (0.23 log units) below; low and high end bracket the measured number.
By their numbers in this assay, from the lowest: compound 1; then compounds 2, 3 and 4 (each within the scatter of the next, the first and the last beyond it).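

At this position, on an aromatic carbon para to a large group, 5-methyl-1,3,4-oxadiazol-2-yl gives a 1.7-fold higher number from compound 3 to compound 4 (0.23 log units; within the scatter) in this assay and a 2.1-fold higher number from compound 2 to compound 4 (0.33 log units; beyond the scatter) against 5-methyl-1,2,4-oxadiazol-3-yl. An exchange among these isomers thus reaches beyond the scatter for the first time, though only modestly and only for that one pair. Nothing available explains the gap between the isomers.

Open, going by these compounds, is whether an amine or a longer chain in place of the methyl on 5-methyl-1,3,4-oxadiazol-2-yl would shift the half-life. Also open, on these data alone, is whether a carboxylic acid at this aromatic carbon would do so.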